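This account rests on a few compounds, and the source may have more. Where it says the series, first, only, none or still open, it means among the compounds named here.

Measured so far:
compound 1, `O=C(CCSc1nc2cc(Cl)ccc2o1)N1CCC1`: 3.7 mL/min/g
compound 2, `Clc1ccc2oc(SCCCN3CCCC3)nc2c1`: 1.9 mL/min/g

Both were tested in an ADME assay on microsomes from liver (Homo sapiens) for metabolic stability, read by LC-MS, using NADPH, with a stated time of 45 min, tested at 0.5 uM; on this read-out higher numbers stand for fast clearance and lower numbers for slow clearance. Within the data shown here, compound 2 gives the lowest of the two numbers; its nearest neighbour is compound 1, and the only measured step, a 1.9-fold lower number from compound 1 to compound 2 (0.29 log units; within the scatter), lies within the scatter, so the two cannot be placed in order. That step changed a group on a saturated chain carbon, two bonds along the chain from a sulfur.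

Compound 3, `O=S1(=O)CCCN1CCCSc1nc2cc(Cl)ccc2o1`, has not yet been measured. It differs from compound 2 in one place: a group of 7 heavy atoms (3 carbon, 1 nitrogen, 2 oxygen, 1 sulfur; one five-membered non-aromatic ring with 2 hetero atoms) in place of a group of 5 heavy atoms (4 carbon, 1 nitrogen; one five-membered non-aromatic ring with 1 hetero atom), on a saturated chain carbon, three bonds along the chain from a sulfur.

Among the measured compounds shown here, the single measured step bears on this change only loosely, since it alters a different group at a different point of the chain, and it did not move the read-out beyond the scatter. Nothing in the data therefore points to a shift in either direction. The estimate for compound 3 in this assay is 2 mL/min/g, with a range from 1 mL/min/g to 4 mL/min/g. This estimate means an expected step of a 1.1-fold higher number from compound 2 to compound 3 (0.02 log units; within the scatter), which is not beyond the scatter.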

Compound 3, intrinsic clearance in a liver preparation (reported as CLH), per the amount of preparation that the assay uses: 4.7 mL/min/g
Beside the measured number, compound 3's estimate is 2.4-fold (0.37 log units) below it; measured number above the stated range.
By their numbers in this assay, from the lowest: compounds 2, 1 and 3 (each within the scatter of the next, the first and the last beyond it).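

In this assay, among these compounds, the exchange of pyrrolidin-1-yl for the five-membered non-aromatic ring with 2 hetero atoms, on a saturated chain carbon, three bonds along the chain from a sulfur, gives a 2.5-fold higher number from compound 2 to compound 3 (0.39 log units; beyond the scatter) and is the first step in this set to lie beyond the scatter. This shows that the read-out can respond to the group at this place, which the earlier step, lying within the scatter, could not show, although the size of the step is only modest and its direction is towards faster clearance. No measurement here bears on this result, so the higher number cannot be assigned to any one feature of the entering group, whether its 2 oxygens, its sulfur or its greater count of heavy atoms.

The compounds shown leave open how a pyrrolidin-2-one or a morpholin-4-yl group would read at this same place, and such groups could help separate the effect of the sulfur and its oxygens from that of the ring itself. They also leave open whether the same exchange would give a similar step on a shorter or a longer chain.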